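Series notes: the step from compound 3 to compound 4

The source may hold more compounds than are shown below. What is called first, only, known or untested is meant among the compounds shown, and "the series" means these compounds.

Three measured compounds share one core. Compound 1 `c1ccc2c(c1)CCC2NC1CCN(CCCc2c[nH]c3ccc(-n4cnnc4)cc23)CC1` gives 25 nM in an assay on CHO cells for agonist activity at 5-hydroxytryptamine receptor 1D (Homo sapiens), read by GTPgammaS binding; a higher number here means that more compound is needed for the effect, a lower number that less compound is needed. Compound 2 `CC(=O)Nc1ccc([C@H](C)NCC2CCN(CCCc3c[nH]c4ccc(-n5cnnc5)cc34)CC2)cc1` gives 3 nM in this assay. Compound 3 `c1ccc(CNCC2CCN(CCCc3c[nH]c4ccc(-n5cnnc5)cc34)CC2)cc1` gives 5.6 nM in this assay and holds the second highest of the three numbers: its nearest neighbour is compound 2, within the scatter, its furthest is compound 1, beyond it. The two steps into compound 3 are a 4.5-fold lower number from compound 1 to compound 3 (0.65 log units; beyond the scatter) and a 1.9-fold higher number from compound 2 to compound 3 (0.27 log units; within the scatter).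

Compound 4 `CN(Cc1cccs1)C1CCN(CCCc2c[nH]c3ccc(-n4cnnc4)cc23)CC1` awaits measurement and differs from compound 3 in one place: methyl((thiophen-2-yl)methyl)amino in place of (benzylamino)methyl on a saturated ring carbon.

Going by the values given here, only the step from compound 1 to compound 3 touches the same saturated ring carbon, and it was modest; the step from compound 2 to compound 3 changed the group on the amine nitrogen and stayed within the scatter. Compound 4 returns to an amino group sitting directly on that ring carbon, as compound 1 has, so a step toward a higher number is expected, smaller than or equal to a 4.5-fold lower number from compound 1 to compound 3 (0.65 log units; beyond the scatter).

For compound 4 the expected step is a 2.1-fold higher number from compound 3 to compound 4 (0.33 log units; beyond the scatter). Compound 4 is estimated at 12 nM in this assay, with a range from 4 nM to 40 nM.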

Compound 4, half-maximal effective concentration: 3.5 nM
For compound 4 the middle estimate is 3.4-fold (0.54 log units) above the measured one; the measured number lies below the stated range.
By their numbers in this assay, from the lowest: compounds 2, 4 and 3 (each within the scatter of the next); then compound 1.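

With a 1.6-fold lower number from compound 3 to compound 4 (0.20 log units; within the scatter) in this assay this saturated ring carbon tolerates methyl((thiophen-2-yl)methyl)amino in place of (benzylamino)methyl, even though the entering group has 0 hydrogen-bond donors against 1 and a five-membered aromatic ring with 1 hetero atom. Compound 1 also has an amino group directly on that ring carbon, yet a 7.1-fold lower number from compound 1 to compound 4 (0.85 log units; beyond the scatter) shows that such an attachment does not by itself give the higher number of compound 1. Nothing measured here explains either step.

The compounds shown do not separate the contribution of the thiophen-2-yl ring from that of the methyl on the amine nitrogen, since the two enter together. Also open, from the compounds shown here alone, is how a pyridine ring or a carboxylic acid on this side chain would read in this assay.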